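This account rests on a few compounds, and the source may have more. Where it says the series, first, only, none or still open, it means among the compounds named here.

Working notes on the series. The shared core carries a chalcone-type side chain, and three compounds have been measured in a functional assay on DU-145 cells (Homo sapiens) for antiproliferative activity, read by MTT assay, with a stated time of 24 h; on this read-out higher numbers stand for weaker inhibition and lower numbers for stronger inhibition. Compound 1 `COc1ccc(-c2cc(C(=O)/C=C/c3ccccc3)nc3cc(-c4ccccc4)nn23)cc1OC` gives 15600 nM. Compound 2 `COc1cc(-c2cc(C(=O)/C=C/c3ccccc3)nc3cc(-c4ccccc4)nn23)cc(OC)c1OC` gives 16300 nM, which is the highest of the three numbers, though its gaps to the other two are within the scatter. Compound 3 `COc1ccc(/C=C/C(=O)c2cc(-c3cc(OC)c(OC)c(OC)c3)n3nc(-c4ccccc4)cc3n2)cc1OC` gives 15300 nM. The two single-point steps are both flat: a 1.0-fold higher number from compound 1 to compound 2 (0.02 log units; within the scatter) and a 1.1-fold lower number from compound 2 to compound 3 (0.03 log units; within the scatter).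

Compound 4 `COc1cc(-c2cc(/C=C/C(=O)c3ccc(C)c(C)c3)nc3cc(-c4ccccc4)nn23)cc(OC)c1OC` is not yet measured. Relative to compound 2 the change is 2-((3,4-dimethylphenyl)carbonyl)ethenyl in place of (2-phenylethenyl)carbonyl on an aromatic carbon. Within the data shown here, no measured step matches this change exactly; the nearest is the step from compound 2 to compound 3, where changing the aryl group on the chalcone chain left the number essentially unmoved, and the step from compound 1 to compound 2 likewise showed that substitution on an aromatic ring did not register. On that basis no step beyond the scatter is expected in this assay, giving an expected 1.0-fold lower number from compound 2 to compound 4 (0.01 log units; within the scatter). Compound 4 is therefore estimated at 16000 nM, with a range of 6000 nM to 45000 nM.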

Compound 4, half-maximal inhibitory concentration: 15400 nM
The estimate for compound 4 lay 1.0-fold (0.02 log units) above the measured number; measured number inside the range.
By their numbers in this assay, from the lowest: compounds 3, 4, 1 and 2 (each within the scatter of the next).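

Until now the side chain had varied only in its aryl group, with the carbonyl bound to the shared core; here, the ethenyl end is bound to the core and the carbonyl carries a 3,4-dimethylphenyl group. In this assay, this turned chain gives a 1.1-fold lower number from compound 2 to compound 4 (0.02 log units; within the scatter), so this position tolerates both the reversal and the larger group of this size without a step beyond the scatter. No measured evidence on the cause of this flat result is available.

The step carries the reversal and the dimethyl substitution together, so a flat outcome does not show what each does alone, and the two could offset each other. Also open, going by these compounds, is whether a chain ending in an amine or a carboxylic acid at this position would move the number beyond the scatter.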